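The source may hold more compounds than are shown below. What is called first, only, known or untested is meant among the compounds shown, and "the series" means these compounds.

Measured so far in a functional assay on A-375 cells (Homo sapiens) for antiproliferative activity; on this read-out lower numbers stand for stronger inhibition and higher numbers for weaker inhibition
- compound 1 `O=C(Nc1ccc(-c2cscn2)cc1)C1CCCN(Cc2ccc(F)c(F)c2)C1` gives 880 nM
- compound 2 `O=C(Nc1ccc(-c2ccncc2)cc1)C1CCCN(Cc2ccc(F)c(F)c2)C1` gives 600 nM
- compound 3 `O=C(Nc1ccc(-c2ccco2)cc1)C1CCCN(Cc2ccc(F)c(F)c2)C1` gives 1040 nM

Compound 3 stands within the scatter of both other compounds, with a 1.2-fold higher number from compound 1 to compound 3 (0.07 log units; within the scatter) and a 1.7-fold higher number from compound 2 to compound 3 (0.24 log units; within the scatter) as its steps, so these three values cannot be ranked.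

The next structure is compound 4 `O=C(Nc1ccc(-c2ccc[nH]2)cc1)C1CCCN(Cc2ccc(F)c(F)c2)C1`, and the change is 1H-pyrrol-2-yl in place of furan-2-yl on an aromatic carbon. It puts 1H-pyrrol-2-yl in place of furan-2-yl on an aromatic carbon of a six-membered aromatic ring of carbon only, para to a large group.

For the measured compounds named here, no measured step involves 1H-pyrrol-2-yl. The nearest evidence is the set of exchanges at this same place, the two steps above and a 1.5-fold lower number from compound 1 to compound 2 (0.17 log units; within the scatter), and all three stay small. No step beyond the scatter is therefore expected in this assay, and no direction can be argued with confidence.

The estimated step is a 1.3-fold lower number from compound 3 to compound 4 (0.11 log units; within the scatter), which is expected to stay within the scatter.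

For compound 4 the estimate is 800 nM, with an expected range from 350 nM to 1800 nM.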

Compound 4, half-maximal inhibitory concentration: 360 nM
For compound 4 the middle estimate is 2.2-fold (0.35 log units) above the measured one, within the range that was stated.
By their numbers in this assay, from the lowest: compounds 4, 2, 1 and 3 (each within the scatter of the next, the first and the last beyond it).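

In this assay, for the compounds shown here, this position is no longer silent: a 2.9-fold lower number from compound 3 to compound 4 (0.46 log units; beyond the scatter) and a 2.4-fold lower number from compound 1 to compound 4 (0.39 log units; beyond the scatter) are the first steps here to pass the scatter, though both are modest. The pattern does not extend to all the groups, as compound 2 goes against it with a 1.7-fold lower number from compound 2 to compound 4 (0.22 log units; within the scatter). The step from compound 3 to compound 4 keeps the same count of heavy atoms and exchanges a hydrogen-bond acceptor for a hydrogen-bond donor, but nothing available links that exchange to the shift in antiproliferative numbers.

From the compounds shown here alone, whether the hydrogen on the ring nitrogen of 1H-pyrrol-2-yl matters remains open, and a 1-methylpyrrol-2-yl group would test this directly. Also open is how this position responds to a group outside the aromatic rings shown, such as an amine or a carboxylic acid.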